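This account rests on a few compounds, and the source may have more. Where it says the series, first, only, none or still open, it means among the compounds named here.

Compound 1 `COc1cccc(C(=O)Oc2cc3c(cc2C)[C@@H](C(C)C)CC=C3C)c1` is the anchor of this note. In a functional assay on HCT-15 cells (Homo sapiens) for antiproliferative activity, read by sulforhodamine B assay, with a stated time of 48 h, tested at 50 uM (a higher number here means more inhibition at the concentration tested (going by the name of the read-out), a lower number less inhibition), compound 1 is reported as "not active" (no number reported), so no single number places it. Among the compounds with values here, compound 2 `Cc1cc2c(C(C)C)ccc(C)c2cc1OC(=O)c1ccc(C(F)(F)F)cc1`, built on a different core and carrying a trifluoromethyl group, gives 55.6% in this assay; no step between the two is given, and the two values show only that compound 2 has a reported number where compound 1 has none. Compound 3 `CC1=CC[C@H](C(C)C)c2cc(C)c(OC(=O)c3ccccc3)cc21` differs from compound 1 as hydrogen in place of methoxy on an aromatic carbon. Within the data shown here, no step is known for this change; any move in this assay is expected to stay within the scatter, with no direction favoured. Compound 3 is expected to give 10% in this assay, within 0% to 35%.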

Compound 3, a percentage reported as inhibition, at one concentration (the size of the read-out at that concentration, not a potency): 49.5%
Compound 3: middle estimate off by 39.5 percentage points, on the low side; the whole stated range lies below it.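

Within the data shown here, compound 1 is reported as "not active" (no number reported) and compound 3 has a number, so no step between them can be read. As far as these compounds go, the size of any shift from 3-methoxyphenyl to phenyl in this assay stays open. No measured evidence bears on this result.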